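Changing the ring on a double-bonded nitrogen

The source may report more compounds than this note shows. Statements on the series, on what has been measured and on what is new or still open speak of the compounds shown alone.

Compound 1 `CCOC(=O)C1=C(N/C=N/c2cccnc2Cl)Nc2[nH]nc(C)c2C1c1ccc(N(C)C)cc1`: 4180 nM
Compound 2 `CCOC(=O)C1=C(NN=C(C#N)C#N)Nc2[nH]nc(C)c2C1c1ccc(N(C)C)cc1`: 12100 nM
Compound 3 `CCOC(=O)C1=C(N/C=N/c2ncc(-c3ccccc3)s2)Nc2[nH]nc(C)c2C1c1ccc(N(C)C)cc1`: 10100 nM

All three numbers come from a functional assay on MCF7 cells (Homo sapiens) for inhibition, read by MTT assay, with a stated time of 48 h (a lower number here means a stronger inhibitor, a higher number a weaker inhibitor), and the compounds share one core. Compound 3 sits at the high end of this small set: at 10100 nM it cannot be told apart from compound 2, and only compound 1 is clearly lower.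

Compound 4 `CCOC(=O)C1=C(N/C=N/c2ccccn2)Nc2[nH]nc(C)c2C1c1ccc(N(C)C)cc1` is still unmeasured. It has pyridin-2-yl in place of 5-phenyl-1,3-thiazol-2-yl on a double-bonded nitrogen, and the rest of compound 3 stays the same.

The closest evidence is the modest step of a 2.4-fold higher number from compound 1 to compound 3 (0.38 log units; beyond the scatter), which has 5-phenyl-1,3-thiazol-2-yl replacing 2-chloropyridin-3-yl at this same place. Pyridin-2-yl resembles 2-chloropyridin-3-yl more than it resembles the group it replaces, so part of that step may be undone. The other measured step, a 2.9-fold higher number from compound 1 to compound 2 (0.46 log units; beyond the scatter), puts a group without a ring on an amine nitrogen and bears only loosely on this change. Among the measured compounds shown here, no measured compound carries pyridin-2-yl itself.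

A small move toward a lower number is therefore expected, probably not clearly beyond the scatter, and the expected step is a 1.7-fold lower number from compound 3 to compound 4 (0.23 log units; within the scatter) in this assay. Compound 4 is estimated at 6000 nM, with an expected range from 2500 nM to 14000 nM.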

Compound 4, half-maximal inhibitory concentration: 37300 nM
Compound 4: middle estimate off by 6.2-fold (0.79 log units), on the low side, and the stated range ends below it.
By their numbers in this assay, from the lowest: compound 1; then compounds 3 and 2 (each within the scatter of the next); then compound 4.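

In this assay compound 4 is the weakest of the four, with an 8.9-fold higher number from compound 1 to compound 4 (0.95 log units; beyond the scatter) and a 3.7-fold higher number from compound 3 to compound 4 (0.57 log units; beyond the scatter) at this place on the double-bonded nitrogen, and the ringless group of compound 2 also gives a lower number, with a 3.1-fold higher number from compound 2 to compound 4 (0.49 log units; beyond the scatter) on the amine nitrogen. The earlier compounds shown here gave no sign that two groups as alike as 2-chloropyridin-3-yl and pyridin-2-yl, each with one six-membered aromatic ring holding one hetero atom, could lie this far apart, so a group's likeness on paper was a poor guide at this position. No measurement shown explains why pyridin-2-yl gives the highest number of the set.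

The compounds shown leave open whether the chlorine or the point at which the ring is attached accounts for the gap between compound 1 and compound 4, a question that pyridin-3-yl at this place would help to separate. They also leave open how much of the lower number of compound 3 depends on its phenyl ring, which 1,3-thiazol-2-yl without that phenyl would test.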